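This account rests on a few compounds, and the source may have more. Where it says the series, first, only, none or still open, it means among the compounds named here.

In a functional assay on HepG2 cells (Homo sapiens) for inhibition, read by MTT assay, with a stated time of 72 h (on this read-out higher numbers stand for weaker inhibition and lower numbers for stronger inhibition), compound 1 `CNC(=O)CCCCCCCn1nc(-c2ccc3oc(N)nc3c2)c2c(N)ncnc21` gives 3640 nM. Compound 2 `Nc1nc2cc(-c3nn(CC(=O)NO)c4ncnc(N)c34)ccc2o1` reaches only the limit > 150000 nM in this assay. Compound 3 `Nc1nc2cc(-c3nn(CCC(=O)NO)c4ncnc(N)c34)ccc2o1` likewise reaches only the limit > 150000 nM in this assay. Compound 3 therefore stands at the limit of > 150000 nM in this assay, at which 2 of the 3 values shown sit, with no number of its own. The steps of an at least 41-fold higher number from compound 1 to compound 2 (1.61 log units; beyond the scatter) and an at least 41-fold higher number from compound 1 to compound 3 (1.61 log units; beyond the scatter) mark the loss seen when the long methylcarbamoyl chain gives way to a short hydroxycarbamoyl group; the step that the two limits leave unreadable from compound 2 to compound 3 cannot be read. Compound 4 `Nc1nc2cc(-c3nn(CCCCCCC(=O)NO)c4ncnc(N)c34)ccc2o1` differs from compound 3 in 4-(hydroxycarbamoyl)butyl in place of hydroxycarbamoyl on a saturated chain carbon, two bonds along the chain from an aromatic nitrogen. Since compound 1 with its long chain gives 3640 nM, a return toward a readable number is expected for compound 4, an at least 75-fold lower number from compound 3 to compound 4 (1.87 log units; beyond the scatter). For compound 4 a value of 2000 nM is expected, within 300 nM to 20000 nM.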

Compound 4, half-maximal inhibitory concentration: 1610 nM
Beside the measured number, compound 4's estimate is 1.2-fold (0.09 log units) above it; the measured number falls inside the stated range.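

At this place, a chain ending in hydroxycarbamoyl gives a readable value in this assay once it reaches 6-(hydroxycarbamoyl)hexyl, with an at least 93-fold lower number from compound 3 to compound 4 (1.96 log units; beyond the scatter) and an at least 93-fold lower number from compound 2 to compound 4 (1.96 log units; beyond the scatter). The two shorter chains, in compound 2 and compound 3, give only a limit and no number: the limit of > 150000 nM in this assay, at which 2 of the 4 values shown sit.
At long chain length, the step of a 2.3-fold lower number from compound 1 to compound 4 (0.35 log units; beyond the scatter) accompanies hydroxycarbamoyl in place of (methylcarbamoyl)methyl, so the chain end also bears on the value.
Still open, going by these compounds, is where between the short chains and 6-(hydroxycarbamoyl)hexyl a readable value first appears. Also open, on these data alone, is how a longer chain, or a carboxylic acid in place of hydroxycarbamoyl, would read.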